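Extending a Chain on a Sulfonamide: Compound 3 Expected

The source may hold more compounds than are shown below. What is called first, only, known or untested is meant among the compounds shown, and "the series" means these compounds.

Compound 1 `CN(C)C(=O)c1cc2cnc(Nc3ccc(S(=O)(=O)NCCCCN=C=S)cc3)nc2n1C1CCCC1` gives 72.7% in a functional assay on NCI-H1299 cells (Homo sapiens) for inhibition, read by CCK-8 assay, with a stated time of 72 h, tested at 10 uM; a higher number here means a stronger effect of the compound at the concentration tested, a lower number a weaker effect.
Compound 2 `CN(C)C(=O)c1cc2cnc(Nc3ccc(S(=O)(=O)NCCCCCCN=C=S)cc3)nc2n1C1CCCC1` gives 70.6% in this assay.

Compound 2 and compound 1 lie within the scatter of each other, so neither can be called the stronger. Compound 3 `CN(C)C(=O)c1cc2cnc(Nc3ccc(S(=O)(=O)NCCCCCCCN=C=S)cc3)nc2n1C1CCCC1` differs from compound 2 by a group of 4 heavy atoms (2 carbon, 1 nitrogen, 1 sulfur; no ring) in place of a group of 3 heavy atoms (1 carbon, 1 nitrogen, 1 sulfur; no ring), on a saturated chain carbon, six bonds along the chain from a sulfonamide nitrogen. Going by the values given here, the only comparable step, a number 2.1 percentage points lower from compound 1 to compound 2 (within the scatter), was also a chain extension at this kind of position and stayed within the scatter. A similar outcome is therefore expected here, with a number 1.6 percentage points lower from compound 2 to compound 3 (within the scatter) and no step beyond the scatter. Compound 3 is estimated at 69%, in a range from 57% to 80%.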

Compound 3, a percentage reported as inhibition, at one concentration (the size of the read-out at that concentration, not a potency): 83%
Compound 3: the middle estimate sits 14 percentage points below what was measured; measured number above the stated range.
By their numbers in this assay, from the lowest: compounds 2 and 1 (each within the scatter of the next); then compound 3.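

In this assay, lengthening this chain turns out not to be silent at every length: the change is a number 12.4 percentage points higher from compound 2 to compound 3 (beyond the scatter), and a number 10.3 percentage points higher from compound 1 to compound 3 (beyond the scatter), whereas the earlier step was a number 2.1 percentage points lower from compound 1 to compound 2 (within the scatter). Across these compounds the response to chain length is therefore not a steady trend, since a difference beyond the scatter appears only with compound 3. Nothing in the data shown explains why it appears at this length.

From the compounds shown here alone, whether a longer chain would hold this gain or lose it remains open. So does the effect of an amine or a carboxylic acid at this place.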